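Estimating Compound 3 After a Group Exchange

The source may report more compounds than this note shows. Statements on the series, on what has been measured and on what is new or still open speak of the compounds shown alone.

- Compound 1 `Cc1cc(CCCOc2c(C)cc(-c3noc(C)n3)cc2C)on1`: 0.45 h
- Compound 2 `COCc1cc(CCCOc2c(C)cc(-c3noc(C)n3)cc2C)on1`: 0.5 h

In an in vitro ADME assay on microsomes from liver (Simiiformes) (on this read-out lower numbers stand for a shorter-lived compound and higher numbers for a longer-lived compound), compound 2 stands at 0.5 h, level with compound 1 within the scatter. Compound 3 `CC(=O)c1ccc(CCCOc2c(C)cc(-c3noc(C)n3)cc2C)o1` is not yet measured. It carries this change: 5-acetylfuran-2-yl in place of 3-(methoxymethyl)-1,2-oxazol-5-yl on a saturated chain carbon, three bonds along the chain from an oxygen on an aromatic ring. Among the compounds with values here, the only measured step, a 1.1-fold higher number from compound 1 to compound 2 (0.05 log units; within the scatter), placed methoxy on a saturated chain carbon and did not exchange the whole group, so it bears only weakly on this change. Going by these compounds, with so little guidance, no step beyond the scatter is expected, and the direction remains open. The expected step is a 1.3-fold lower number from compound 2 to compound 3 (0.10 log units; within the scatter). Compound 3 is estimated at 0.4 h, with an expected range of 0.18 h to 0.85 h.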

Compound 3, half-life: 0.617 h
The estimate for compound 3 lay 1.5-fold (0.19 log units) below the measured number, and the stated range covers the measured number.
By their numbers in this assay, from the lowest: compounds 1, 2 and 3 (each within the scatter of the next).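

In this assay the whole ring at this place could be exchanged, with the nitrogen-containing ring giving way to 5-acetylfuran-2-yl, and the result was a 1.2-fold higher number from compound 2 to compound 3 (0.09 log units; within the scatter) and a 1.4-fold higher number from compound 1 to compound 3 (0.14 log units; within the scatter). Within these three compounds, neither exchange of the group moved the half-life beyond the scatter, and nothing available explains this. The compounds leave open whether an amine or a carboxylic acid in place of the acetyl, or a longer chain, would give a step beyond the scatter.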